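This account rests on a few compounds, and the source may have more. Where it says the series, first, only, none or still open, it means among the compounds named here.

Measured so far:
compound 1 `O=C(Nc1cc(C(F)(F)F)cc(C(F)(F)F)c1)C1CCc2ccccc2N1C(=O)c1ccccc1Cl` with 8040 nM
compound 2 `CCCC(=O)N1c2ccccc2CCC1C(=O)Nc1cc(C(F)(F)F)cc(C(F)(F)F)c1` with 18600 nM

Compound 1 is the parent of the pair; in a functional assay on PC-3 cells (Homo sapiens) for cytotoxicity, read by sulforhodamine B assay, with a stated time of 72 h (on this read-out higher numbers stand for weaker inhibition of growth and lower numbers for stronger inhibition of growth), compound 1 gives 8040 nM. Compound 2 `CCCC(=O)N1c2ccccc2CCC1C(=O)Nc1cc(C(F)(F)F)cc(C(F)(F)F)c1` carries propyl in place of 2-chlorophenyl on the carbonyl carbon and gives 18600 nM, the higher of the two numbers measured; the step of a 2.3-fold higher number from compound 1 to compound 2 (0.36 log units; beyond the scatter) lies beyond the scatter, so compound 2 is the weaker growth inhibitor of the two.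

Compound 3 `O=C(Nc1cc(C(F)(F)F)cc(C(F)(F)F)c1)C1CCc2ccccc2N1C(=O)c1ccc(Cl)cc1` is not yet measured. Relative to compound 2 the change is 4-chlorophenyl in place of propyl on a carbonyl carbon. Among the measured compounds shown here, the one measured step that bears on it is a 2.3-fold higher number from compound 1 to compound 2 (0.36 log units; beyond the scatter), which went the opposite way: removing an aryl group from that carbonyl carbon raised the number by a modest amount. Putting an aryl group back, here 4-chlorophenyl rather than 2-chlorophenyl, is therefore expected to lower the number by a comparable modest amount, roughly returning to the level of compound 1; the expected step is a 2.3-fold lower number from compound 2 to compound 3 (0.37 log units; beyond the scatter). Compound 3 is estimated at 8000 nM, with a range from 3500 nM to 18000 nM.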

Compound 3, concentration for 50% growth inhibition: 4230 nM
The estimate for compound 3 lay 1.9-fold (0.28 log units) above the measured number; low and high end bracket the measured number.
By their numbers in this assay, from the lowest: compounds 3 and 1 (each within the scatter of the next); then compound 2.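

In this assay, 4-chlorophenyl in place of propyl on the carbonyl carbon gives a 4.4-fold lower number from compound 2 to compound 3 (0.64 log units; beyond the scatter) and thus a larger step than the earlier 2.3-fold higher number from compound 1 to compound 2 (0.36 log units; beyond the scatter) in the reverse direction, so both chlorophenyl groups now read lower than propyl at this position. Exchanging one chlorophenyl group for the other gives a 1.9-fold lower number from compound 1 to compound 3 (0.28 log units; within the scatter) and so leaves compound 1 and compound 3 without any order between them: moving the chlorine from the 2-chlorophenyl to the 4-chlorophenyl arrangement has no readable consequence on these numbers. No measurement at hand accounts for the difference between the chlorophenyl groups and propyl.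

The compounds shown leave open whether the chlorine contributes at all or whether a plain phenyl on the same carbonyl carbon would read alike, and how a longer chain, an amine or a carboxylic acid would read there. As far as these compounds go, all three compounds also share the rest of the core, including its trifluoromethyl groups, so whether the propyl-to-chlorophenyl step holds with other groups on that side remains untested in this set.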